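Benzylamine sulfonamides in A2780 growth inhibition: compound 4

The source may hold more compounds than are shown below. What is called first, only, known or untested is meant among the compounds shown, and "the series" means these compounds.

Measured so far in a functional assay on A2780 cells (Homo sapiens) for inhibition, read by MTT assay, with a stated time of 72 h; on this read-out higher numbers stand for weaker inhibition of growth and lower numbers for stronger inhibition of growth:
compound 1, `O=S(=O)(NCCCCNCc1ccc(Br)cc1)c1cc(C(F)(F)F)cc(C(F)(F)F)c1`, 2100 nM
compound 2, `O=S(=O)(NCCNCc1ccc(-c2ccccc2)cc1)c1cc(C(F)(F)F)cc(C(F)(F)F)c1`, 2600 nM
compound 3, `COc1ccc(CNCCCNS(=O)(=O)c2cc(C(F)(F)F)cc(C(F)(F)F)c2)cc1OC`, 3800 nM

The three compounds share a bis(trifluoromethyl)phenylsulfonamide core and differ in the length of the saturated chain and in the group on the benzyl ring. Compound 3 sits at the upper end of the three numbers in this assay, yet both compound 2 and compound 1 lie within the scatter of it, so the three read as one cluster rather than a ranked set. Within the data shown here, no single-point step between measured compounds is available for comparison.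

Compound 4, `O=S(=O)(NCCCNCc1ccc(C(F)(F)F)cc1)c1cc(C(F)(F)F)cc(C(F)(F)F)c1`, is the next member to be measured. It differs from compound 3 as follows: 4-(trifluoromethyl)phenyl in place of 3,4-dimethoxyphenyl on a saturated chain carbon bound to an amine nitrogen. Since bromo, phenyl and dimethoxy substitution on that ring all gave numbers within the scatter of one another, the step of a 1.4-fold lower number from compound 3 to compound 4 (0.13 log units; within the scatter) is expected to be small and to remain within the scatter, with no clear direction. In this assay compound 4 is expected to give about 2800 nM, with a range from 1200 nM to 6500 nM, because compound 3 gives 3800 nM and compound 1 gives 2100 nM with a related change at the same place.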

Compound 4, concentration for 50% growth inhibition: 2800 nM
Compound 4: middle estimate and measured number agree at the digits printed; the range from low to high includes it.
By their numbers in this assay, from the lowest: compounds 1, 2, 4 and 3 (each within the scatter of the next).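

Exchanging 3,4-dimethoxyphenyl for 4-(trifluoromethyl)phenyl on a saturated chain carbon bound to an amine nitrogen gives a 1.4-fold lower number from compound 3 to compound 4 (0.13 log units; within the scatter) in this assay, so the two compounds cannot be told apart on this read-out. Among these compounds, this is the first comparison with only one place changed, whereas the earlier compounds differed in chain and ring together; here, a group with 2 hydrogen-bond acceptors and one with 0, each of 10 heavy atoms, leave the number within the scatter at this position on the chain shared by the pair. No measurement is at hand that would account for this insensitivity.

The separate contribution of chain length cannot be read from the compounds shown, and the observation at this position rests on a single pair. As far as these compounds go, it remains open whether the same tolerance would hold for a carboxylic acid or a primary amine on the benzyl ring, or for an amide in place of the amine nitrogen.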